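The source may report more compounds than this note shows. Statements on the series, on what has been measured and on what is new or still open speak of the compounds shown alone.

The measured compounds:

Compound 1, `CC1CCC(=NNc2ccccc2)c2ncc(C(=O)O)c(=O)n21`, gives 1.2 umol/kg in a functional assay on the whole organism with Rattus norvegicus as the target; a lower number here means that less compound is needed, a higher number that more compound is needed for the effect.
Compound 2, `Cc1cccc(NN=C2CCC(C)n3c2ncc(C(=O)O)c3=O)c1C`, reaches only the limit of this assay, > 100 umol/kg.
Compound 3, `CC1CCC(=NNc2ccc(Cl)c(Cl)c2)c2ncc(C(=O)O)c(=O)n21`, likewise reaches only the limit, > 100 umol/kg.

Compound 2 therefore stands at the limit, and no number is known for it; the same limit holds for compound 3, as noted in the limit of > 100 umol/kg in this assay, at which 2 of the 3 values shown sit. Only compound 1 carries a number.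

Compound 4, `Cc1cccc(Cl)c1NN=C1CCC(C)n2c1ncc(C(=O)O)c2=O`, has not yet been measured. It differs from compound 2 in one place: 2-chloro-6-methylphenyl in place of 2,3-dimethylphenyl on an amine nitrogen.

Going by the values given here, two measured steps bear on this change. The step of an at least 83-fold higher number from compound 1 to compound 2 (1.92 log units; beyond the scatter) and the step of an at least 83-fold higher number from compound 1 to compound 3 (1.92 log units; beyond the scatter) both show that replacing the plain phenyl on the amine nitrogen by a phenyl bearing further groups pushes the compound to the limit. The step that the two limits leave unreadable from compound 2 to compound 3 cannot be read, as both ends sit at the limit. Compound 4 keeps a phenyl with further groups on that nitrogen, so compound 4 is expected to remain near the limit, with the step that the limit leaves unreadable from compound 2 to compound 4 estimated as small or unreadable. Compound 4 is thus estimated at 150 umol/kg, within 30 umol/kg to 1000 umol/kg.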

Compound 4, dose for 50% inhibition: > 100 umol/kg
Compound 4: no number, only a limit (the forecaster's own chance of this, stated with the estimate: 70%); the middle value is on the limit's open side.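

In this assay the 2-chloro-6-methylphenyl group on the amine nitrogen ends up where the two earlier substituted phenyls did, with an at least 83-fold higher number from compound 1 to compound 4 (1.92 log units; beyond the scatter). Carrying a chlorine together with a methyl therefore brings no number back, and among the compounds shown only the plain phenyl of compound 1 gives a readable value. Compound 2, compound 3 and compound 4 carry limits and not numbers, so the steps among them cannot be read: the limit of > 100 umol/kg in this assay, at which 3 of the 4 values shown sit.

Still open, on these data alone, is whether a single small group on the phenyl, such as one fluorine or one methyl, keeps a number in this assay as the read-out. Also open, as far as these compounds go, are how compound 2, compound 3 and compound 4 truly rank against each other, and what a pyridine ring in place of the phenyl would give.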